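Benzyl halogen swap in the imidazole series: cytotoxicity

A few compounds are considered here, and "the series" means these few. Any claim that something is new, unique, unknown or untested is made for them only; others in the source may bear on it.

Compound 1, `COC(=O)c1ccc(NCc2cncn2Cc2ccc(Cl)cc2)cc1-c1ccccc1`: in a toxicity assay on NIH3T3 cells (Mus musculus) for cytotoxicity, read by resazurin assay (on this read-out higher numbers stand for an effect only at larger amounts of compound and lower numbers for an effect already at smaller amounts), compound 1 gives 25000 nM.
Compound 2, `c1ccc(-c2ccc(Cn3cncc3CNc3cccc(-c4ccccc4)c3)cc2)cc1`: compound 2 gives 10000 nM.
Compound 3, `Clc1ccc(Cn2cncc2CNc2ccc(-c3nc4ccccc4s3)c(-c3ccccc3)c2)cc1`: compound 3 gives > 1000 nM, which is a limit of the assay and not a number.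

Compound 1 stands highest of the two numbers; compound 2 gives a lower number, and that gap is beyond the usual scatter. For compound 3 only the limit of > 1000 nM in this assay, at which 1 of the 3 values shown sits, is known, so the step that the limit leaves unreadable from compound 1 to compound 3 cannot be read in size.

Compound 4, `COC(=O)c1ccc(NCc2cncn2Cc2ccccc2Br)cc1-c1ccccc1`, differs from compound 1 by 2-bromophenyl in place of 4-chlorophenyl on a saturated chain carbon bound to an aromatic nitrogen. For the measured compounds named here, none of the measured steps touches this part of the structure: the only computed step concerns the group on the aromatic carbon, and it is unreadable. The two numbers of compound 1 and compound 2 differ at the aromatic carbon and at the benzyl halogen at once, so they do not isolate this change either. Going by the values given here, with no step bearing on it, no change beyond the scatter is expected; the estimated step is no change at the digits printed from compound 1 to compound 4 (within the scatter). Compound 4 is therefore expected at about 25000 nM, between 10000 nM and 60000 nM.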

Compound 4, half-maximal effective concentration: 10000 nM
Estimate against measurement, compound 4: 2.5-fold (0.40 log units) above; low and high end bracket the measured number.
By their numbers in this assay, from the lowest: compounds 2 and 4 (each within the scatter of the next); then compound 1.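

In this assay, for the compounds shown here, 2-bromobenzyl in place of 4-chlorobenzyl gives a 2.5-fold lower number from compound 1 to compound 4 (0.40 log units; beyond the scatter), the first readable step. Going by these compounds alone, the step is modest, but it shows that this place, a saturated chain carbon bound to an aromatic nitrogen, can move the read-out with the rest of compound 1 unchanged; the only earlier step, at an aromatic carbon, cannot be read. Nothing shown here accounts for the step.

The change swaps the halogen and moves it on the ring at once, and a 2-chlorobenzyl or 4-bromobenzyl group would tell these two apart. On these data alone, how an unsubstituted benzyl group or a longer chain ending in phenyl would read at this place also remains open.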